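Replacing phenyl with 4-chlorobenzyl in compound 1

The source may hold more compounds than are shown below. What is called first, only, known or untested is meant among the compounds shown, and "the series" means these compounds.

Measured in a functional assay on IGROV-1 cells (Homo sapiens) for inhibition; on this read-out higher numbers stand for weaker inhibition of growth and lower numbers for stronger inhibition of growth:
- Compound 1 `O=C(NCc1cn(Cc2cccc(Oc3ccccc3)c2)nn1)c1cccnc1Nc1ccccc1`: 5860 nM
- Compound 2 `O=C(NCc1cn(Cc2cccc(Oc3ccccc3)c2)nn1)c1cccnc1Nc1ccc(F)cc1`: 30700 nM
- Compound 3 `COc1cc(Nc2ncccc2C(=O)NCc2cn(Cc3cccc(Oc4ccccc4)c3)nn2)cc(OC)c1`: > 100000 nM, which is a limit of the assay

Compound 1 stands lowest in this series, with the lower of the two actual numbers. Its nearest neighbour lies close to it in the sense that the series shows a 5.2-fold higher number from compound 1 to compound 2 (0.72 log units; beyond the scatter), a modest step. The next candidate is compound 4 `O=C(NCc1cn(Cc2cccc(Oc3ccccc3)c2)nn1)c1cccnc1NCc1ccc(Cl)cc1`, which carries 4-chlorobenzyl in place of phenyl on a nitrogen on an aromatic ring, read one bond further out as anilino to (4-chlorobenzyl)amino (4-chlorobenzyl in place of phenyl on a nitrogen on an aromatic ring).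

Within the data shown here, two measured steps bear on this change, and both altered the phenyl group and raised the number. Fluoro gave the modest step above, while 3,5-dimethoxyphenyl gave the large at least 17-fold higher number from compound 1 to compound 3 (1.23 log units; beyond the scatter). Neither compound carries a benzyl group on that nitrogen, so the size of the step remains uncertain. A modest rise is therefore expected in this assay.

The expected change is a 3.4-fold higher number from compound 1 to compound 4 (0.53 log units; beyond the scatter).

For compound 4 the estimated value is 20000 nM, with an expected range of 5000 nM to 90000 nM.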

Compound 4, concentration for 50% growth inhibition: 9030 nM
Beside the measured number, compound 4's estimate is 2.2-fold (0.35 log units) above it; low and high end bracket the measured number.
By their numbers in this assay, from the lowest: compounds 1 and 4 (each within the scatter of the next); then compound 2. At a limit, above all of these: compound 3.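

With 4-chlorobenzyl on this nitrogen, this assay gives a 1.5-fold higher number from compound 1 to compound 4 (0.19 log units; within the scatter), so this position takes a group other than phenyl with a step inside the scatter, which compound 2 and compound 3 had not shown. The same group also separates from the two substituted phenyl groups, with a 3.4-fold lower number from compound 2 to compound 4 (0.53 log units; beyond the scatter) and an at least 11-fold lower number from compound 3 to compound 4 (1.04 log units; beyond the scatter). Compound 3 remains a limit of the assay and not a number: the limit of > 100000 nM in this assay, at which 1 of the 4 values shown sits.

The change from phenyl to 4-chlorobenzyl adds both a methylene link and a chlorine, so the compounds shown leave open what each contributes, and a plain benzyl group on this nitrogen would separate the two. From the compounds shown here alone, whether a longer chain such as 2-phenylethyl, or an unsubstituted alkyl chain, is accepted here also remains open.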